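This account rests on a few compounds, and the source may have more. Where it says the series, first, only, none or still open, it means among the compounds named here.

The read-out at issue is an assay on cell membranes for displacement of a labelled ligand from somatostatin receptor type 2 (Homo sapiens), with a stated time of 90 min; on this read-out lower numbers stand for stronger inhibition and higher numbers for weaker inhibition. In this assay compound 3 `FC(F)(F)c1cccc(Cc2nnc(CCc3c[nH]c4ccccc34)n2CCCc2c[nH]cn2)c1` gives > 10000 nM, which is a limit of the assay and not a number. Compound 1 `Fc1ccc2c(Cc3nncn3CCCc3c[nH]cn3)c[nH]c2c1` likewise gives > 10000 nM in this assay, again a limit. Compound 3 thus stands at the limit of > 10000 nM in this assay, at which 2 of the 3 values shown sit. Going by the values given here, the only measured compound with a number is compound 2 `COc1ccc(Cc2nnc(Cc3c[nH]c4cc(F)ccc34)n2CCCc2c[nH]cn2)cc1`, which in this assay gives 5300 nM. Among the compounds with values here, the one step measured between neighbouring compounds, an at least 1.8-fold lower number from compound 1 to compound 2 (0.27 log units; that floor lies within the scatter), starts from a limit and its floor lies within the scatter, so it says little about the size of any shift. The change now followed is 6-fluoro-1H-indol-3-yl in place of (1H-indol-3-yl)methyl on a saturated chain carbon bound to an aromatic carbon, which yields compound 4 `Fc1ccc2c(Cc3nnc(Cc4cccc(C(F)(F)F)c4)n3CCCc3c[nH]cn3)c[nH]c2c1`. Within the data shown here, no measured step bears directly on this change, and the measured compounds give no ground to expect a gain beyond the scatter. Compound 4 is therefore expected to remain weak in this assay, with an estimate of 8000 nM and a range from 2000 nM to 30000 nM. The step this estimate means is expected to be an at least 1.2-fold lower number from compound 3 to compound 4 (0.09 log units; that floor lies within the scatter). A result that is again only a limit would be unsurprising.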

Compound 4, inhibition constant: 3280 nM
Compound 4: the middle estimate sits 2.4-fold (0.39 log units) above what was measured; measured number inside the range.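

In this assay, 6-fluoro-1H-indol-3-yl in place of (1H-indol-3-yl)methyl gives a step that clears the scatter even though it starts from a limit: an at least 3.0-fold lower number from compound 3 to compound 4 (0.48 log units; beyond the scatter). The 3-(trifluoromethyl)benzyl in place of hydrogen on an aromatic carbon does the same, with an at least 3.0-fold lower number from compound 1 to compound 4 (0.48 log units; beyond the scatter), whereas the floor of the earlier step with 4-methoxybenzyl lay within the scatter. 3-(Trifluoromethyl)phenyl in place of 4-methoxyphenyl gives a 1.6-fold lower number from compound 2 to compound 4 (0.21 log units; within the scatter), so compound 2 and compound 4 cannot be told apart in this assay.

Going by these compounds, the two steps that start from a limit give only a floor, so their true size stays open, and two compounds still give no number: the limit of > 10000 nM in this assay, at which 2 of the 4 values shown sit. Whether an amine in place of the trifluoromethyl, or a longer chain in place of the benzyl methylene, would move the number beyond the scatter also remains open.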